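A few compounds are considered here, and "the series" means these few. Any claim that something is new, unique, unknown or untested is made for them only; others in the source may bear on it.

In a functional assay on MCF7 cells (Homo sapiens) for antiproliferative activity, read by MTT assay, with a stated time of 48 h (on this read-out lower numbers stand for stronger inhibition and higher numbers for weaker inhibition), compound 1 `CCCCCCCCn1cc(COC[C@@H]2OC[C@H](N)[C@@H]2O)nn1` gives 28100 nM, and compound 2 `CCCCCCCCCCCCCCn1cc(COC[C@@H]2OC[C@H](N)[C@@H]2O)nn1`, with a longer chain, gives 1850 nM. Compound 3 `CCCCCCCCn1cc(COC[C@@H]2OC[C@H](N)[C@H]2O)nn1` gives > 128000 nM, which is a limit of the assay and not a number. Among the compounds with values here, it is the only one of these three compounds without a measured value.

Compound 4 `CCCCCCCCCCCCn1cc(COC[C@@H]2OC[C@H](N)[C@H]2O)nn1` arises from compound 3 through a single change, (butyl in place of hydrogen on a saturated chain carbon, eight bonds along the chain from an aromatic nitrogen). Within the data shown here, the closest precedent is a 15-fold lower number from compound 1 to compound 2 (1.18 log units; beyond the scatter), which came from hexyl in place of hydrogen at the same place on the chain. This is one pair only, and it was measured in the configuration of compound 1. Whether it carries over to the configuration of compound 3 has not been measured. The other measured change, an at least 4.5-fold higher number from compound 1 to compound 3 (0.65 log units; beyond the scatter), reflects (the fact that compounds 1 and 3 differ only in the configuration as drawn), and its size is open-ended because of the limit of > 128000 nM in this assay, at which 1 of the 3 values shown sits.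

The smaller butyl addition is therefore expected to give a large move towards lower numbers, though less than the hexyl step, and the estimated change is an at least 8.5-fold lower number from compound 3 to compound 4 (0.93 log units; beyond the scatter). Compound 4 is estimated at 15000 nM, within an expected range of 4000 nM to 60000 nM.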

Compound 4, half-maximal inhibitory concentration: 2620 nM
Beside the measured number, compound 4's estimate is 5.7-fold (0.76 log units) above it; measured number below the stated range.
By their numbers in this assay, from the lowest: compounds 2 and 4 (each within the scatter of the next); then compound 1. At a limit, above all of these: compound 3.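

Within the data shown here, the chain addition at this place had so far been seen only in the configuration of compound 1, as a 15-fold lower number from compound 1 to compound 2 (1.18 log units; beyond the scatter). It also holds in the configuration of compound 3: butyl in place of hydrogen on a saturated chain carbon, eight bonds along the chain from an aromatic nitrogen, gives an at least 48-fold lower number from compound 3 to compound 4 (1.68 log units; beyond the scatter), so this configuration does not by itself keep the number out of the measurable range. Compound 3 stands at a limit and not at a number, so the true size of this step stays open-ended: the limit of > 128000 nM in this assay, at which 1 of the 4 values shown sits.

Open, from the compounds shown here alone, is how much the configuration still matters once the chain is longer, which a pair with the same longer chain in both configurations would settle. Also open, going by these compounds, is whether a still longer chain, or a phenyl group at the chain end, would move the number further.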